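Tetrahydroisoquinoline Variant of Compound 1 Awaiting Measurement

The compounds below may be only part of what the source reports. "The series", "measured", "known", "first", "only" and "open" are said of these compounds alone.

Compound 1, `CS(=O)(=O)c1ccc(C(=O)NCCC(=O)N2CCCc3ccccc32)cc1[N+](=O)[O-]`: in an assay on isolated protein for inhibition of vitamin D3 receptor (Homo sapiens), read by fluorescence polarization (a higher number here means a weaker inhibitor, a lower number a stronger inhibitor), compound 1 gives > 60000 nM, a limit of the assay.
Compound 2, `CN(CC(=O)N1CCN(c2ccc(F)cc2)CC1)C(=O)c1ccc(S(C)(=O)=O)c([N+](=O)[O-])c1`: in this assay compound 2 gives > 60000 nM, likewise a limit.

Compound 1 therefore stands at the limit of > 60000 nM in this assay, at which 2 of the 2 values shown sit, with no number of its own. Compound 3, `CS(=O)(=O)c1ccc(C(=O)NCCC(=O)N2CCc3ccccc3C2)cc1[N+](=O)[O-]`, differs from compound 1 in one place: 1,2,3,4-tetrahydroisoquinolin-2-yl in place of 1,2,3,4-tetrahydroquinolin-1-yl on a carbonyl carbon. Among the measured compounds shown here, no step between measured compounds is recorded. In this assay no change beyond the usual scatter is expected from compound 1 to compound 3, and a limit rather than a number is anticipated. Compound 3 is estimated at 80000 nM, within 30000 nM to 250000 nM. The expected step is a step that the limit leaves unreadable from compound 1 to compound 3.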

Compound 3, half-maximal inhibitory concentration: > 60000 nM
Compound 3: only a limit was reported; the forecaster's own chance of this, stated with the estimate: 85%; the middle value is on the limit's open side.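

Compound 1 and compound 3 both rest at a limit in this assay, so no step can be read between them: the limit of > 60000 nM in this assay, at which 3 of the 3 values shown sit.

The compounds shown leave open how 1,2,3,4-tetrahydroisoquinolin-2-yl and 1,2,3,4-tetrahydroquinolin-1-yl compare, since neither gives an actual number.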